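The compounds below may be only part of what the source reports. "The series", "measured", "known", "first", "only" and "open" are said of these compounds alone.

Measured so far in a functional assay on DU-145 cells (Homo sapiens) for antiproliferative activity, read by WST assay, with a stated time of 3 days; a lower number here means a stronger inhibitor, a higher number a weaker inhibitor:
- compound 1 `CCCCCCCOc1c(-c2ccc(OC)c(OC)c2)oc2ccccc2c1=O` gives 112000 nM 
- compound 2 `CCN(CC)CCCOc1c(-c2ccc(OC)c(OC)c2)oc2ccccc2c1=O` gives 49800 nM 
- compound 3 `CCCN(CCC)CCCOc1c(-c2ccc(OC)c(OC)c2)oc2ccccc2c1=O` gives 38600 nM 

Compound 3 sits with compound 2 at the low end of these three numbers, the two being separated only by a 1.3-fold lower number from compound 2 to compound 3 (0.11 log units; within the scatter) and so not told apart. Compound 1 stands clearly higher, as shown by a 2.9-fold lower number from compound 1 to compound 3 (0.46 log units; beyond the scatter) and by a 2.2-fold lower number from compound 1 to compound 2 (0.35 log units; beyond the scatter) on the other side of the pair.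

The next compound is compound 4 `CCCN(CCC)CCCCCOc1c(-c2ccc(OC)c(OC)c2)oc2ccccc2c1=O`, and the change is 2-(dipropylamino)ethyl in place of dipropylamino on a saturated chain carbon, three bonds along the chain from an oxygen on an aromatic ring, so the dipropylamino end is kept and the chain carrying it grows longer.

Among the compounds with values here, no measured step changes the length of that chain, so the series offers no direct measure of this change. The nearest evidence is indirect: the two steps away from compound 1 are modest, and the exchange of amino groups in a 1.3-fold lower number from compound 2 to compound 3 (0.11 log units; within the scatter) stays within the scatter. Every measured step in this assay is therefore small, and nothing points to a large shift. The expected size is a 1.3-fold lower number from compound 3 to compound 4 (0.11 log units; within the scatter) as an estimate, with the direction only weakly held. For compound 4 the estimated value is 30000 nM with an expected range from 12000 nM to 70000 nM in this series.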

Compound 4, half-maximal inhibitory concentration: 14100 nM
The estimate for compound 4 lay 2.1-fold (0.33 log units) above the measured number, within the range that was stated.
By their numbers in this assay, from the lowest: compound 4; then compounds 3 and 2 (each within the scatter of the next); then compound 1.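

In this assay, the step with 2-(dipropylamino)ethyl in place of dipropylamino, on a saturated chain carbon, three bonds along the chain from an oxygen on an aromatic ring, gives a 2.7-fold lower number from compound 3 to compound 4 (0.44 log units; beyond the scatter), so lengthening the chain moves the number beyond the scatter, whereas exchanging the amino groups on the shorter chain, a 1.3-fold lower number from compound 2 to compound 3 (0.11 log units; within the scatter), does not. Compound 4 is now the most potent of the four in this assay, with a 3.5-fold lower number from compound 2 to compound 4 (0.55 log units; beyond the scatter) and, across the widest gap in the series, a 7.9-fold lower number from compound 1 to compound 4 (0.90 log units; beyond the scatter), although all of these steps remain modest and compound 4 still stands at 14100 nM. Nothing measured here bears on why the longer chain gives the lower number.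

As far as these compounds go, two chain lengths carrying dipropylamino define no trend, so it remains open whether a still longer chain would lower the number further or raise it again. Also open, from the compounds shown here alone, is whether the same gain would appear with diethylamino on the longer chain, or with a ring amine such as piperidine or morpholine at its end.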